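The source may hold more compounds than are shown below. What is called first, only, known or untested is meant among the compounds shown, and "the series" means these compounds.

Compound 1 `CC(C)(C)OC(=O)CCC[N+]1(C)CCc2c(sc(NC(=O)Nc3ccc(Cl)cc3)c2C(N)=O)C1` gives 250 nM in a functional assay (strain AB) with Danio rerio as the target, read by microscopy, with a stated time of 1 h; on this read-out higher numbers stand for an effect only at larger amounts of compound and lower numbers for an effect already at smaller amounts
Compound 2 `CN1CCc2c(sc(NC(=O)Nc3ccc(Cl)cc3)c2C(N)=O)C1` gives 4700 nM in this assay
Compound 3 `CC(C)N1CCc2c(sc(NC(=O)Nc3ccc(Cl)cc3)c2C(N)=O)C1` gives 1490 nM in this assay

Compound 1 has the lowest number of the three, with compound 3 nearest and compound 2 furthest, both gaps beyond the scatter. Compound 4 `C[N+]1(CC2CCCC2)CCc2c(sc(NC(=O)Nc3ccc(Cl)cc3)c2C(N)=O)C1` differs from compound 1 as follows: cyclopentyl in place of 2-(tert-butoxycarbonyl)ethyl on a saturated chain carbon bound to an amine nitrogen in a ring, cyclopentyl in place of 2-(tert-butoxycarbonyl)ethyl. Within the data shown here, the only measured step, a 3.2-fold lower number from compound 2 to compound 3 (0.50 log units; beyond the scatter), is modest and concerns a different change, so it bears only loosely. Among the measured compounds shown here, no measured step covers this exchange, and compound 1 stands at the low end (250 nM), so a modest rise is expected. The estimated step is a 2.4-fold higher number from compound 1 to compound 4 (0.38 log units; beyond the scatter) in this assay, toward a higher number. Compound 4 is estimated at 600 nM, with 170 nM to 2000 nM as the expected range.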

Compound 4, half-maximal effective concentration: 200 nM
Estimate against measurement, compound 4: 3.0-fold (0.48 log units) above; measured number inside the range.
By their numbers in this assay, from the lowest: compounds 4 and 1 (each within the scatter of the next); then compound 3; then compound 2.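

Cyclopentyl in place of 2-(tert-butoxycarbonyl)ethyl gives a 1.3-fold lower number from compound 1 to compound 4 (0.10 log units; within the scatter) in this assay, so the two compounds cannot be told apart on this read-out. At this place, on a saturated chain carbon bound to an amine nitrogen in a ring, the ester is therefore not needed for a number of this size: a carbon-only ring with no hydrogen-bond acceptors serves as well. No evidence bears on why the two groups read alike. Still open, on these data alone, is how a carboxylic acid or a terminal amine on the chain would read, and whether a phenyl ring would match cyclopentyl.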